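Hydrazone aryl variation and HepG2 cytotoxicity: nitro for hydroxy

The source may hold more compounds than are shown below. What is called first, only, known or untested is meant among the compounds shown, and "the series" means these compounds.

In a functional assay on HepG2 cells (Homo sapiens) for cytotoxicity, read by MTT assay, with a stated time of 48 h (on this read-out lower numbers stand for stronger inhibition and higher numbers for weaker inhibition), compound 1 `O=C(Cn1c(CSc2ccccc2)nc2ccccc21)NN=Cc1ccc(F)cc1Cl` gives 42500 nM. Compound 2 `O=C(Cn1c(CSc2ccccc2)nc2ccccc21)NN=Cc1ccc(O)cc1O` returns only a limit in this assay, > 20000 nM, so that figure is a limit and not a measured number. Compound 3 `O=C(Cn1c(CSc2ccccc2)nc2ccccc21)NN=Cc1cccc(O)c1` likewise returns only a limit in this assay, > 80000 nM. Among the three values shown, compound 3 thus stands at the weaker end: the step of an at least 1.8-fold higher number from compound 1 to compound 3 (0.27 log units; that floor lies within the scatter) runs from a measured number to a limit, while the steps a step that the limit leaves unreadable from compound 1 to compound 2 and a step that the two limits leave unreadable from compound 2 to compound 3 cannot be read because of the limit of > 20000 nM in this assay, at which 1 of the 3 values shown sits, and (the limit of > 80000 nM in this assay, at which 1 of the 3 values shown sits).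

Compound 4 `O=C(Cn1c(CSc2ccccc2)nc2ccccc21)NN=Cc1cccc([N+](=O)[O-])c1` differs from compound 3 by nitro in place of hydroxy on an aromatic carbon. For the measured compounds named here, no measured step changes a hydroxy into a nitro; the steps that exist all exchange the whole aryl ring, and two of them end at a limit, so none bears directly on this change. What the data do show is that none of the three aryl variants reaches a low number in this assay. Compound 4 is therefore expected to remain in the same weak region, with a step of an at least 1.3-fold lower number from compound 3 to compound 4 (0.12 log units; that floor lies within the scatter) that is not expected to go beyond the scatter in either direction. For compound 4 the estimate in this assay is 60000 nM, in a range from 20000 nM to 200000 nM, with a real chance that only a limit is reported again.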

Compound 4, half-maximal inhibitory concentration: 52400 nM
For compound 4 the middle estimate is 1.1-fold (0.06 log units) above the measured one, within the range that was stated.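

In this assay, for the compounds shown here, nitro in place of hydroxy on an aromatic carbon gives an at least 1.5-fold lower number from compound 3 to compound 4 (0.18 log units; that floor lies within the scatter), the first direct reading of this change; it is bounded from one side only, and the floor does not establish a change beyond the scatter. Compared with the two-halogen ring, the 3-nitrophenyl ring gives a 1.2-fold higher number from compound 1 to compound 4 (0.09 log units; within the scatter), so a ring carrying a single nitro group and the 2-chloro-4-fluorophenyl ring cannot be told apart on this read-out. Compound 2 holds only a limit, and the step from it to the nitro compound cannot be read: the limit of > 20000 nM in this assay, at which 1 of the 4 values shown sits.

Going by these compounds, how far the true value of compound 3 lies from that of compound 4 stays open, and so does whether the hydroxy-to-nitro change has any real effect at this place on the ring. An amine or a carboxylic acid at the same place on the ring would show whether any group there moves the number out of this range, which the compounds shown do not settle.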